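From Compound 2 to Compound 4: An Expected Shift

The source may hold more compounds than are shown below. What is called first, only, known or untested is meant among the compounds shown, and "the series" means these compounds.

Compound 1 `Nc1nc(N)c2cc(CSC(=S)N3CCN(c4ccc(O)cc4)CC3)ccc2n1` gives 5090 nM in a functional assay on MCF7 cells (Homo sapiens) for antiproliferative activity, read by MTT assay, with a stated time of 72 h; a lower number here means a stronger inhibitor, a higher number a weaker inhibitor.
Compound 2 `COc1ccc(N2CCN(C(=S)SCc3ccc4nc(N)nc(N)c4c3)CC2)cc1` gives 1580 nM in this assay.
Compound 3 `Nc1nc(N)c2cc(CSC(=S)N3CCN(c4ccccc4Cl)CC3)ccc2n1` gives 3190 nM in this assay.

Compound 2 holds the lowest number of the three and is the strongest inhibitor here: the nearest gap is a 2.0-fold higher number from compound 2 to compound 3 (0.31 log units; beyond the scatter), the furthest is a 3.2-fold lower number from compound 1 to compound 2 (0.51 log units; beyond the scatter). Compound 4 `Nc1nc(N)c2cc(CSC(=S)N3CCN(c4ccc(Cl)c(Cl)c4)CC3)ccc2n1` differs from compound 2 by 3,4-dichlorophenyl in place of 4-methoxyphenyl on an amine nitrogen in a ring. The step that bears on this is a 2.0-fold higher number from compound 2 to compound 3 (0.31 log units; beyond the scatter), where 2-chlorophenyl replaced 4-methoxyphenyl on the amine nitrogen in the ring; the related step of a 1.6-fold lower number from compound 1 to compound 3 (0.20 log units; within the scatter) stayed within the scatter. A further chlorine-bearing phenyl in place of 4-methoxyphenyl is therefore expected to raise the number modestly, so compound 4 is expected to show a 1.6-fold higher number from compound 2 to compound 4 (0.22 log units; within the scatter). Compound 4 is estimated at 2600 nM, with a range from 1200 nM to 5600 nM.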

Compound 4, half-maximal inhibitory concentration: 2370 nM
Estimate against measurement, compound 4: 1.1-fold (0.04 log units) above; the range from low to high includes it.
By their numbers in this assay, from the lowest: compounds 2, 4, 3 and 1 (each within the scatter of the next, the first and the last beyond it).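

Two chlorines on the phenyl at this place leave the number within the scatter of both neighbours: a 1.5-fold higher number from compound 2 to compound 4 (0.18 log units; within the scatter), and a 1.3-fold lower number from compound 3 to compound 4 (0.13 log units; within the scatter). Compound 2 and compound 4 thus cannot be separated, so 3,4-dichlorophenyl can stand in for 4-methoxyphenyl here, while the step against the 4-hydroxyphenyl of compound 1 goes beyond the scatter, with a 2.1-fold lower number from compound 1 to compound 4 (0.33 log units; beyond the scatter). No measurement shown here accounts for these steps.

Going by these compounds, it remains open whether a non-aromatic group such as cyclohexyl on the same ring nitrogen would keep this level. The same holds for a phenyl bearing an amine.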